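From cyano to fluoro: estimating compound 4

A few compounds are considered here, and "the series" means these few. Any claim that something is new, unique, unknown or untested is made for them only; others in the source may bear on it.

In a physicochemical assay for lipophilicity (a lower number here means a more polar compound, a higher number a more lipophilic compound), compound 2 `CC(C)OC[C@H](Oc1ncnc2c1cnn2-c1ncccc1Cl)C(=O)Nc1ccc(C#N)cn1` gives 2.5, the middle of three measured numbers. Compound 1 `CC(C)OC[C@H](Oc1ncnc2c1cnn2-c1ncccc1Cl)C(=O)Nc1ccc(Cl)cn1` stands higher at 3.5, and compound 3 `CCOC[C@H](Oc1ncnc2c1cnn2-c1ncccc1Cl)C(=O)Nc1ccc(C#N)cn1` stands lower at 2.

The unmeasured compound 4 `CC(C)OC[C@H](Oc1ncnc2c1cnn2-c1ncccc1Cl)C(=O)Nc1ccc(F)cn1` differs from compound 2 at a single place: fluoro in place of cyano on an aromatic carbon. In short, it has fluoro in place of cyano on an aromatic carbon.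

Closest to this change is a number 1.00 log units lower from compound 1 to compound 2 (beyond the scatter), which put cyano in place of chloro on that same aromatic carbon. The other measured step, a number 0.50 log units lower from compound 2 to compound 3 (beyond the scatter), lies on the saturated chain, away from this carbon, so it offers little guidance here.

Read backwards, the first step shows the number rising when cyano gives way to chloro. Fluoro is not chloro, however, and no measured compound carries it, so the rise can only be judged roughly. Some of that rise is expected to appear, but not all of it. The estimate is therefore an upward move, expected to be a number 0.50 log units higher from compound 2 to compound 4 (beyond the scatter). For compound 4 the expected value in this assay is 3, with an estimated range from 2.7 to 3.4.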

Compound 4, distribution coefficient: 2.7
Compound 4: the middle estimate sits 0.30 log units above what was measured; measured number inside the range.
By their numbers in this assay, from the lowest: compound 3; then compounds 2 and 4 (each within the scatter of the next); then compound 1.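

In this assay the change from 5-cyanopyridin-2-yl to 5-fluoropyridin-2-yl gives a number 0.20 log units higher from compound 2 to compound 4 (within the scatter), so the two groups cannot be told apart at this position, even though cyano brings 2 heavy atoms and a hydrogen-bond acceptor while fluoro brings 1 heavy atom and no acceptor. Among the three groups seen on this aromatic carbon, chloro is the one that stands apart: fluoro in its place gives a number 0.80 log units lower from compound 1 to compound 4 (beyond the scatter), and cyano in its place gives a number 1.00 log units lower from compound 1 to compound 2 (beyond the scatter), so both steps lie beyond the scatter. Nothing in the available data explains why chloro separates from the other two groups.

The compounds shown leave open where other groups on this carbon, such as an amine, a methoxy group or a carboxylic acid, would fall relative to these three. They also leave open whether fluoro and cyano would stay within the scatter of each other on the shorter ether chain of compound 3, since fluoro appears here only with the chain of compound 2.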